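A few compounds are considered here, and "the series" means these few. Any claim that something is new, unique, unknown or untested is made for them only; others in the source may bear on it.

Going by the values given here, in a functional assay on SW-620 cells (Homo sapiens) for cytotoxicity, read by MTT assay, with a stated time of 48 h (on this read-out lower numbers stand for stronger inhibition and higher numbers for weaker inhibition), compound 1 (`COc1cc(C(=O)c2cn(-c3cccc(N)c3)cc2-c2ccccc2F)cc(OC)c1OC`) gives 123 nM and compound 2 (`COc1cc(C(=O)c2cn(-c3cccc(N)c3)cc2-c2ccccc2[N+](=O)[O-])cc(OC)c1OC`) gives 38 nM, the lower of the two numbers so far. Compound 3 (`COc1cc(C(=O)c2cn(-c3cccc(N)c3)cc2-c2ccc(N)cc2)cc(OC)c1OC`) has 4-aminophenyl in place of 2-nitrophenyl on an aromatic carbon. Among the compounds with values here, only one measured step bears on this place: nitro in place of fluoro, a 3.2-fold lower number from compound 1 to compound 2 (0.51 log units; beyond the scatter), modest and beyond the scatter. It is an imperfect guide. Within the data shown here, no measured compound carries an amino group on this aryl group, and none has a substituent at the 4-position. Among the measured compounds shown here, with a 3.2-fold lower number from compound 1 to compound 2 (0.51 log units; beyond the scatter) as the sole guide, a change of similar modest size or smaller is expected in this assay, leaning towards a higher number, with the direction uncertain. The expected step is a 1.8-fold higher number from compound 2 to compound 3 (0.27 log units; within the scatter). For compound 3 the estimate is 70 nM, with an expected range of 18 nM to 280 nM.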

Compound 3, half-maximal inhibitory concentration: 28 nM
Compound 3: middle estimate off by 2.5-fold (0.40 log units), on the high side; the range from low to high includes it.
By their numbers in this assay, from the lowest: compounds 3 and 2 (each within the scatter of the next); then compound 1.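

In this assay, the step of a 1.4-fold lower number from compound 2 to compound 3 (0.13 log units; within the scatter) shows that this place accepts 4-aminophenyl as well as 2-nitrophenyl, so a substituent on this aryl group need not stand at the 2-position, and an amino group can match a nitro group here. The step of a 4.4-fold lower number from compound 1 to compound 3 (0.64 log units; beyond the scatter) puts 2-fluorophenyl apart from both other groups, and compound 1 now has steps beyond the scatter to compound 2 and to compound 3. No evidence on the compounds accounts for these steps.

The change from compound 2 to compound 3 swaps the substituent and its ring position together, and the compounds shown do not separate the two; 2-aminophenyl and 4-nitrophenyl would do so. Unsubstituted phenyl and a 4-carboxyphenyl or 4-dimethylaminophenyl group at this place also remain open.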